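The source may hold more compounds than are shown below. What is called first, only, known or untested is meant among the compounds shown, and "the series" means these compounds.

Compound 2 `CCN(CC)CCNc1nc(-c2ccc(NC(=O)Nc3ccc(Cl)cc3Cl)cc2)nc2c(Cl)c(Cl)sc12` gives the higher of the two numbers recorded in a functional assay on NCI-H460 cells (Homo sapiens) for cytotoxicity, read by MTT assay, with a stated time of 72 h (a lower number here means a stronger inhibitor, a higher number a weaker inhibitor), where compound 2 gives 1300 nM. Within the data shown here, its nearest neighbour is compound 1 `CCN(CC)CCNc1nc(-c2ccc(NC(=O)Nc3ccc(Cl)cc3)cc2)nc2c(Cl)c(Cl)sc12`, which in this assay gives 320 nM; the step of a 4.1-fold higher number from compound 1 to compound 2 (0.61 log units; beyond the scatter) is the only measured step, and it shows that the second chloro on the aryl urea raised the number. Compound 3 `CCN(CC)CCNc1nc(-c2ccc(NC(=O)Nc3ccc(C)cc3)cc2)nc2c(Cl)c(Cl)sc12` carries the change (4-methylphenyl in place of 2,4-dichlorophenyl on an amide-type nitrogen). Among the measured compounds shown here, one part of that change, removal of the chloro added between compound 1 and compound 2, reverses the measured step, so a return toward the number of compound 1 is expected; the other part, methyl in place of chloro on the remaining position, has no measured counterpart, and no direction can be assigned to it. Compound 3 is therefore expected to move by a 3.3-fold lower number from compound 2 to compound 3 (0.51 log units; beyond the scatter), toward a lower number, with the estimate for compound 3 at 400 nM and a range of 150 nM to 1200 nM.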

Compound 3, half-maximal inhibitory concentration: 840 nM
The estimate for compound 3 lay 2.1-fold (0.32 log units) below the measured number; the range from low to high includes it.
By their numbers in this assay, from the lowest: compound 1; then compounds 3 and 2 (each within the scatter of the next).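

In this assay, replacing 2,4-dichlorophenyl with 4-methylphenyl on the amide-type nitrogen gives a 1.5-fold lower number from compound 2 to compound 3 (0.19 log units; within the scatter) and so does not separate these two groups. Among these compounds, the comparison the earlier compounds lacked is methyl in place of chloro on an aromatic carbon, which gives a 2.6-fold higher number from compound 1 to compound 3 (0.42 log units; beyond the scatter) and leaves compound 1 with the lowest number of the three, so this position responds to more than the added chloro of compound 2. Nothing available here explains either step.

Going by these compounds, whether a 4-fluorophenyl, a 4-methoxyphenyl or an unsubstituted phenyl on that nitrogen would fall with compound 1 or with compound 3 remains open. On these data alone, it is also open whether a 2,4-dimethylphenyl would stand with compound 2 and compound 3 or apart from them.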